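From a Dimethylphenyl Amide to Its Pyridyl Analogue

The compounds below may be only part of what the source reports. "The series", "measured", "known", "first", "only" and "open" are said of these compounds alone.

Three compounds built on one shared core have been examined in a toxicity assay on HepG2 cells (Homo sapiens) for inhibition, read by CellTiter-Glo, with a stated time of 48 h; on this read-out higher numbers stand for weaker inhibition and lower numbers for stronger inhibition. Compound 1, `COc1ccc2nc(C)c(NC(=O)C(=O)Nc3cc(C)cc(C)c3)c(O)c2c1`, gives in this assay only a limit of > 100000 nM. Compound 2, `COc1ccc2nc(C)cc(OCC(=O)Nc3c(C)cccc3C)c2c1`, likewise reaches only the limit of > 100000 nM in this assay. Compound 3, `COc1ccc2nc(C)cc(OCC(=O)Nc3cc(OC)c(OC)c(OC)c3)c2c1`, also returns only a limit of > 100000 nM. Compound 2 therefore stands where every measured value stands, namely at the limit of > 100000 nM in this assay, at which 3 of the 3 values shown sit; no number separates it from compound 1 or compound 3, and nothing can be said about any order among the three.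

Compound 4, `COc1ccc2nc(C)cc(OCC(=O)Nc3cccnc3)c2c1`, has not yet been measured. It differs from compound 2 in one place: pyridin-3-yl in place of 2,6-dimethylphenyl on an amide-type nitrogen. No measured pair differing in a single place exists among these compounds, so the only guide is that all three measured values sit at the limit. The expected step is a step that the limit leaves unreadable from compound 2 to compound 4, none beyond the scatter. For compound 4 the estimate is 150000 nM, with a range from 50000 nM to 500000 nM, and this assay is expected most likely to report only a limit once more.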

Compound 4, half-maximal inhibitory concentration: > 100000 nM
Compound 4: a limit, no number (the forecaster's own chance of this, stated with the estimate: 85%); the middle value lies beyond the limit too.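

Compound 4, like compound 2, returns only a limit in this assay, so no step can be read between the two compounds: the limit of > 100000 nM in this assay, at which 4 of the 4 values shown sit. The compounds shown leave open at what concentration, if any, any of them would reach half-maximal inhibition in this assay, and whether pyridin-3-yl and 2,6-dimethylphenyl differ there at all.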